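A Ring in Place of Dimethylamino on a Shared Core

A few compounds are considered here, and "the series" means these few. Any claim that something is new, unique, unknown or untested is made for them only; others in the source may bear on it.

In a functional assay on HeLa cells (Homo sapiens) for cytotoxicity, with a stated time of 72 h (on this read-out higher numbers stand for lower toxicity in this test and lower numbers for higher toxicity in this test), compound 2 (`CN(C)C1=NN(c2ccc(Cl)cc2)CN(c2ccccc2Cl)C1=O`) gives 39.4 ug/mL and compound 1 (`O=C1C(N2CCCC2)=NN(c2ccccc2)CN1c1ccccc1Cl`) gives 44.3 ug/mL so the two stand within the usual scatter of each other. Compound 3 (`O=C1C(N2CCCC2)=NN(c2ccc(Cl)cc2)CN1c1ccccc1Cl`) has pyrrolidin-1-yl in place of dimethylamino on a carbon with a double bond to nitrogen. Among the compounds with values here, no measured pair shows this change alone. Compound 1 already carries pyrrolidin-1-yl and gives 44.3 ug/mL so no step beyond the scatter is expected in this assay here. The estimated change is a 1.0-fold higher number from compound 2 to compound 3 (0.01 log units; within the scatter) and it stays within the scatter. Compound 3 is expected at 40 ug/mL with 20 ug/mL to 80 ug/mL as the estimated range.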

Compound 3, half-maximal cytotoxic concentration: > 50 ug/mL
Compound 3 gave a limit, no number; the forecaster's own chance of this, stated with the estimate: 3%; middle value at least 1.2-fold (0.09 log units) away from the limit.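

Compound 3 reaches a limit in this assay, not a number: the limit of > 50 ug/mL in this assay, at which 1 of the 3 values shown sits. At this position, pyrrolidin-1-yl in place of dimethylamino gives an at least 1.2-fold higher number from compound 2 to compound 3 (0.10 log units; that floor lies within the scatter), while chloro in place of hydrogen on the aromatic carbon gives an at least 1.1-fold higher number from compound 1 to compound 3 (0.05 log units; that floor lies within the scatter). As far as these compounds go, both steps are only floors, so the pyrrolidin-1-yl ring and the added chloro are each compatible with a number this high, but the true size of either step remains unknown. From the compounds shown here alone, whether piperidin-1-yl or diethylamino at this position would give a similar read-out stays open.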